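Moving the fluorine around the phenyl ring

A few compounds are considered here, and "the series" means these few. Any claim that something is new, unique, unknown or untested is made for them only; others in the source may bear on it.

Going by the values given here, compound 2 `Oc1ccc(-c2cc(-c3cccc(F)c3)cc(-c3cccc(O)c3)n2)cc1` is one of only two compounds measured in a functional assay on HCT-15 cells (Homo sapiens) for inhibition (on this read-out higher numbers stand for weaker inhibition and lower numbers for stronger inhibition), where compound 2 gives 3070 nM. Its nearest neighbour is compound 1 `Oc1ccc(-c2cc(-c3ccccc3F)cc(-c3cccc(O)c3)n2)cc1`, which in this assay gives 5630 nM; the step of a 1.8-fold lower number from compound 1 to compound 2 (0.26 log units; within the scatter) lies within the scatter, so the two values cannot be ranked against each other. Compound 3 `Oc1ccc(-c2cc(-c3ccc(F)cc3)cc(-c3cccc(O)c3)n2)cc1` has not yet been measured. It differs from compound 2 in one place: 4-fluorophenyl in place of 3-fluorophenyl on an aromatic carbon. Among the compounds with values here, the only step that bears on this change is the earlier relocation of the fluorine from compound 1 to compound 2, which stayed within the scatter. A similar outcome is therefore expected for compound 3, with a step of a 1.0-fold lower number from compound 2 to compound 3 (0.01 log units; within the scatter) that should not exceed the scatter in either direction. Compound 3 is estimated to give 3000 nM in this assay, with a range from 1200 nM to 7500 nM.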

Compound 3, half-maximal inhibitory concentration: 5020 nM
Compound 3: middle estimate off by 1.7-fold (0.22 log units), on the low side; low and high end bracket the measured number.
By their numbers in this assay, from the lowest: compounds 2, 3 and 1 (each within the scatter of the next).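

With compound 3, the fluorine has been tried at all three places on this phenyl ring, which sits opposite the ring nitrogen, and in this assay none of the placements separates from the others. The change from 3-fluorophenyl to 4-fluorophenyl gives a 1.6-fold higher number from compound 2 to compound 3 (0.21 log units; within the scatter), and the change from 2-fluorophenyl to 4-fluorophenyl gives a 1.1-fold lower number from compound 1 to compound 3 (0.05 log units; within the scatter), so the position of the fluorine on this ring makes no readable difference on this read-out in these three compounds. No supporting data are available to explain this result.

The compounds shown leave open whether a group other than fluorine at this ring would move the number beyond the scatter, such as a chlorine, a methoxy group or an amine. From the compounds shown here alone, it is also open how a plain phenyl ring without fluorine would compare with these three compounds.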